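Amide nitrogen substituent replacements in a weak series

A few compounds are considered here, and "the series" means these few. Any claim that something is new, unique, unknown or untested is made for them only; others in the source may bear on it.

Compound 1 `COc1cc2nccc(Oc3ccc(Nc4nn(C)cc4C(=O)NOCc4ccccc4)cc3)c2cc1C(N)=O` is the reference point, read in a functional assay on BaF3 cells (Mus musculus) for antiproliferative activity, read by CCK-8 assay and cell counting, with a stated time of 76 h; on this read-out higher numbers stand for weaker inhibition and lower numbers for stronger inhibition. In this assay compound 1 gives > 10000 nM, which is a limit of the assay rather than a number. Compound 2 `COc1cc2nccc(Oc3ccc(Nc4nn(C)cc4C(=O)Nc4cccc(F)c4)cc3)c2cc1C(N)=O` gives 4480 nM in this assay. Compound 3 `COc1cc2nccc(Oc3ccc(Nc4nn(C)cc4C(=O)Nc4ccccc4)cc3)c2cc1C(N)=O` gives > 10000 nM, again only a limit. Two of the three values therefore sit at the limit of > 10000 nM in this assay, at which 2 of the 3 values shown sit. The measured steps all exchange the group on the amide-type nitrogen or its substituent: an at least 2.2-fold lower number from compound 1 to compound 2 (0.34 log units; beyond the scatter); a step that the two limits leave unreadable from compound 1 to compound 3; an at least 2.2-fold higher number from compound 2 to compound 3 (0.34 log units; beyond the scatter).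

Compound 4 `COc1cc2nccc(Oc3ccc(Nc4nn(C)cc4C(=O)NC4CCCCC4)cc3)c2cc1C(N)=O` has not yet been measured in this assay. It differs from compound 1 by cyclohexyl in place of benzyloxy on an amide-type nitrogen. The steps bearing on it are the two that also remove benzyloxy from the amide-type nitrogen, from compound 1 to compound 2 and from compound 1 to compound 3, one at least modest downward, one unreadable. Among the compounds with values here, no measured step puts a non-aromatic ring in this place. Since compound 1 stands at a limit, the expected outcome is no step beyond the scatter, a number no higher from compound 1 to compound 4 (the limit leaves the size open). Compound 4 is estimated at 10000 nM, with a range from 3000 nM to 30000 nM, and a reported limit is considered likelier than a number.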

Compound 4, half-maximal inhibitory concentration: 4800 nM
Estimate against measurement, compound 4: 2.1-fold (0.32 log units) above, and the stated range covers the measured number.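

In this assay, a non-aromatic ring on the amide-type nitrogen gives a measured number: cyclohexyl in place of benzyloxy gives an at least 2.0-fold lower number from compound 1 to compound 4 (0.31 log units; beyond the scatter), and cyclohexyl in place of phenyl gives an at least 2.0-fold lower number from compound 3 to compound 4 (0.31 log units; beyond the scatter). An aromatic ring at this place is therefore not needed for a measured number, and cyclohexyl in place of 3-fluorophenyl gives a 1.1-fold higher number from compound 2 to compound 4 (0.03 log units; within the scatter), so compound 2 and compound 4 cannot be told apart here. The steps from compound 1 and compound 3 are bounds only, and their full size stays open: the limit of > 10000 nM in this assay, at which 2 of the 4 values shown sit.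

Going by these compounds, what a short chain such as ethyl or a ring carrying an amine such as piperidine would give on this nitrogen remains open. Also open, on these data alone, is whether a fluoro on cyclohexyl would shift the number as it does on phenyl.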